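Adding a Chloro Group to a Substituted Urea Series

The compounds below may be only part of what the source reports. "The series", "measured", "known", "first", "only" and "open" are said of these compounds alone.

Compound 1: `O=C(Nc1cccc(-n2cc(-c3ccncc3)c(-c3ccc(Cl)c(O)c3)n2)c1)Nc1cccc(C(F)(F)F)c1`, 960 nM
Compound 2: `COc1cc(-c2nn(-c3cccc(NC(=O)Nc4cc(C(F)(F)F)cc(C(F)(F)F)c4)c3)cc2-c2ccncc2)ccc1Cl`, 400 nM
Compound 3: `COc1cc(-c2nn(-c3cccc(NC(=O)Nc4cccc(C(F)(F)F)c4)c3)cc2-c2ccncc2)ccc1Cl`, 310 nM

Of the compounds shown here, three have been measured in a functional assay on SF-295 cells (Homo sapiens) for inhibition, read by sulforhodamine B assay, with a stated time of 48 h; a higher number here means a weaker inhibitor, a lower number a stronger inhibitor. Compound 3 has the lowest number of the three, though the nearest step is a 1.3-fold lower number from compound 2 to compound 3 (0.11 log units; within the scatter), which lies within the scatter, so those two cannot be ranked against each other. Against compound 1 the step is a 3.1-fold lower number from compound 1 to compound 3 (0.49 log units; beyond the scatter), a modest but real difference.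

Compound 4, `COc1cc(-c2nn(-c3cccc(NC(=O)Nc4ccc(Cl)c(C(F)(F)F)c4)c3)cc2-c2ccncc2)ccc1Cl`, is not yet measured. It differs from compound 3 in one place: chloro in place of hydrogen on an aromatic carbon. Going by the values given here, only one measured step touches the same ring of the urea, the one from compound 2 to compound 3, where a substituent was removed from that ring and the number barely moved. That step was within the scatter, so a substituent change on this ring has so far mattered little. Compound 4 is therefore expected to land close to compound 3, with a step of a 1.2-fold lower number from compound 3 to compound 4 (0.08 log units; within the scatter), and its estimated value in this assay is 260 nM, within a range from 110 nM to 620 nM.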

Compound 4, half-maximal inhibitory concentration: 840 nM
For compound 4 the middle estimate is 3.2-fold (0.51 log units) below the measured one, and the stated range ends below it.
By their numbers in this assay, from the lowest: compounds 3 and 2 (each within the scatter of the next); then compounds 4 and 1 (each within the scatter of the next).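

Turning the 3-(trifluoromethyl)phenyl group of the urea into 4-chloro-3-(trifluoromethyl)phenyl gives a 2.7-fold higher number from compound 3 to compound 4 (0.43 log units; beyond the scatter) in this assay and so makes the compound a weaker inhibitor, which shows that this ring does not tolerate every added group equally. Going by these compounds alone, the only earlier step on this ring, a 1.3-fold lower number from compound 2 to compound 3 (0.11 log units; within the scatter) and within the scatter, gave no such sign, so one change on the ring now registers and another does not. Nothing measured here explains the loss from adding a chloro group.

From the compounds shown here alone, whether the loss belongs to chloro itself or to this place on the ring remains open, and a fluoro or methyl group on the same carbon, or a chloro on another carbon of that ring, would help separate the two. Whether an amine or a methoxy group there would be tolerated is also unknown, as is whether the step holds in other cell lines.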